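Trimming the allyl chain of compound 1 to methyl

This account rests on a few compounds, and the source may have more. Where it says the series, first, only, none or still open, it means among the compounds named here.

Compound 1 `C=CCn1c(=O)/c(=C\c2ccccc2Cl)[nH]c(=O)/c1=C\c1ccccc1OC`: 4200 nM
Compound 2 `C=CCn1c(=O)/c(=C\c2cc(Br)ccc2F)[nH]c(=O)/c1=C\c1ccccc1OC`: 17400 nM

Going by the values given here, in a functional assay on HL-60 cells (Homo sapiens) for cytotoxicity, read by CCK-8 assay, with a stated time of 72 h (a lower number here means a stronger inhibitor, a higher number a weaker inhibitor), compound 1 gives 4200 nM, the lower of the two numbers so far, which makes it the stronger inhibitor of the pair. Compound 3 `COc1ccccc1/C=c1\c(=O)[nH]/c(=C/c2ccccc2Cl)c(=O)n1C` keeps the core of compound 1 and differs from it in a single change: hydrogen in place of vinyl on a saturated chain carbon bound to an aromatic nitrogen. In words, this is hydrogen in place of vinyl on a saturated chain carbon bound to an aromatic nitrogen, so the allyl chain becomes methyl.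

Among the compounds with values here, no measured step touches this place, so the data offer no direct guide. Within the data shown here, the only step available is a 4.1-fold higher number from compound 1 to compound 2 (0.62 log units; beyond the scatter), made with 5-bromo-2-fluorophenyl in place of 2-chlorophenyl. It serves only as a yardstick for how far one change has moved the number here. A modest step of no greater size is therefore expected in this assay, leaning weakly towards a higher number, though it may not clear the scatter. The expected step is a 1.5-fold higher number from compound 1 to compound 3 (0.19 log units; within the scatter). For compound 3 the estimated value is 6500 nM, with an expected range of 1800 nM to 22000 nM.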

Compound 3, half-maximal inhibitory concentration: 200 nM
Compound 3: middle estimate off by 33-fold (1.51 log units), on the high side; the measured number lies below the stated range.
By their numbers in this assay, from the lowest: compound 3; then compound 1; then compound 2.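

In this assay, taking away the vinyl end of the allyl chain, so that hydrogen stands in its place and methyl remains, gives a 21-fold lower number from compound 1 to compound 3 (1.32 log units; beyond the scatter) and so marks a large step, well beyond the usual scatter. The result shows that this place, on a saturated chain carbon bound to an aromatic nitrogen, has a strong hold on the number, which the earlier pair could not show since it differed only in the aryl group. That earlier swap of 5-bromo-2-fluorophenyl for 2-chlorophenyl gave a 4.1-fold higher number from compound 1 to compound 2 (0.62 log units; beyond the scatter) and thus moved the number the opposite way and by less, but no measurement available here explains why the methyl compound gives the lower number.

Only allyl and methyl are shown at this place, so it remains open whether an ethyl or propyl chain would give a number nearer to that of compound 1 or compound 3, and whether a chain ending in an amine or a carboxylic acid would be tolerated. On these data alone, it is also open whether the same change would lower the number just as far in compound 2, which carries the 5-bromo-2-fluorophenyl group.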